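Pyrazolyl in place of dimethylamino on the propyl chain

The compounds below may be only part of what the source reports. "The series", "measured", "known", "first", "only" and "open" are said of these compounds alone.

Notes on the series. In an assay on HEK293 cells for agonist activity at Toll-like receptor 8 (Homo sapiens), read by spectrophotometry (a lower number here means that less compound is needed, a higher number that more compound is needed for the effect), compound 2 `CCCCNc1nc(N)nc(C)c1CCCN(C)C` gives 126 nM, the lowest of the three numbers measured; its nearest neighbour is compound 1 `CCCCNc1nc(N)nc(C)c1CCc1ccccc1`, which in this assay gives 1190 nM, and furthest away is compound 3 `CCCC#Cc1c(C)nc(N)nc1NCCCC`, which in this assay gives 5000 nM. The two measured steps both run through compound 2: a 9.4-fold lower number from compound 1 to compound 2 (0.98 log units; beyond the scatter), and a 40-fold higher number from compound 2 to compound 3 (1.60 log units; beyond the scatter).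

Compound 4 `CCCCNc1nc(N)nc(C)c1CCCn1cccn1` differs from compound 2 in one place: 1H-pyrazol-1-yl in place of dimethylamino on a saturated chain carbon, three bonds along the chain from an aromatic carbon. The change keeps the three-carbon chain of compound 2 and exchanges the nitrogen-bearing group at its end for a five-membered aromatic ring. The step from compound 1 to compound 2 bears on this most directly, since it shows what an aromatic ring at the chain end does against a dimethylamino group; the step from compound 2 to compound 3 shows the larger cost of removing the chain nitrogen altogether. Compound 4 retains ring nitrogens, so a rise smaller than either step is expected in this assay, in the direction of a higher number: a 4.0-fold higher number from compound 2 to compound 4 (0.60 log units; beyond the scatter). Compound 4 is therefore estimated at 500 nM, within a range from 150 nM to 2000 nM.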

Compound 4, half-maximal effective concentration: 1050 nM
The estimate for compound 4 lay 2.1-fold (0.32 log units) below the measured number; the measured number falls inside the stated range.
By their numbers in this assay, from the lowest: compound 2; then compounds 4 and 1 (each within the scatter of the next); then compound 3.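

Against this assay, exchanging dimethylamino for 1H-pyrazol-1-yl on a saturated chain carbon, three bonds along the chain from an aromatic carbon, gives an 8.3-fold higher number from compound 2 to compound 4 (0.92 log units; beyond the scatter), so the low number of compound 2 does not survive every nitrogen-bearing group at this chain end, and the nitrogens of the pyrazole ring do not restore it. Compound 4 also sits level with the phenyl-ended compound, with a 1.1-fold lower number from compound 1 to compound 4 (0.05 log units; within the scatter), so among these three compounds both aromatic-ended chains read alike and only the dimethylamino compound stands apart, a comparison that the step between compound 1 and compound 2 alone could not make. Nothing measured in this set accounts for either step.

Open, as far as these compounds go, is whether the low number is particular to dimethylamino or extends to other amines at the chain end, such as a primary amine, a pyrrolidine or a morpholine. Also open, from the compounds shown here alone, is how an amide at the same place would read, and whether a longer chain carrying dimethylamino would hold the number of compound 2.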